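The compounds below may be only part of what the source reports. "The series", "measured", "known", "first", "only" and "open" are said of these compounds alone.

In a functional assay on NCI-H157 cells (Homo sapiens) for antiproliferative activity, read by sulforhodamine B assay, with a stated time of 48 h, tested at 0.1 uM (on this read-out higher numbers stand for more inhibition of growth at the one concentration tested and lower numbers for less inhibition of growth), three compounds have values so far:

- compound 1 `Fc1ccc(-c2nn3c(-c4ccncc4)nnc3s2)cc1Cl` gives 43.6%
- compound 2 `Fc1ccc(OCc2nn3c(-c4ccncc4)nnc3s2)cc1` gives 21.3%
- compound 3 `Oc1ccc(OCc2nn3c(-c4ccncc4)nnc3s2)cc1` gives 52.6%

Compound 3 lies within the scatter of compound 1 and beyond the scatter of compound 2. Compound 4 `COc1ccc(OCc2nn3c(-c4ccncc4)nnc3s2)cc1` differs from compound 3 by methyl in place of hydrogen on an oxygen on an aromatic ring, which turns hydroxy into methoxy.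

Within the data shown here, only one measured step bears on this change. It is a number 31.3 percentage points higher from compound 2 to compound 3 (beyond the scatter), with hydroxy in place of fluoro on an aromatic carbon, and it is large and beyond the scatter. That step shows how much the value moved in one pair when the hydroxy group was exchanged, but methoxy itself has not been measured, so this is thin ground. A downward step in this assay is expected, probably smaller than the measured one and perhaps not clearly beyond the scatter. The estimate means an expected a number 14.6 percentage points lower from compound 3 to compound 4 (beyond the scatter) in this series. Compound 4 is estimated at 38%, with an expected range from 20% to 56%.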

Compound 4, percent growth inhibition at one concentration: 57.2%
The estimate for compound 4 lay 19.2 percentage points below the measured number, outside the stated range (above it).
By their numbers in this assay, from the lowest: compound 2; then compounds 1, 3 and 4 (each within the scatter of the next, the first and the last beyond it).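

In this assay, methyl in place of hydrogen on this oxygen gives a number 4.6 percentage points higher from compound 3 to compound 4 (within the scatter), so the hydroxy and methoxy compounds cannot be told apart and, in this pair, a free hydrogen on that oxygen is not needed to keep the read-out. Methoxy in place of fluoro gives a number 35.9 percentage points higher from compound 2 to compound 4 (beyond the scatter), which matches a number 31.3 percentage points higher from compound 2 to compound 3 (beyond the scatter) and sets fluoro apart from both oxygen-linked groups at this place in these three compounds. Nothing available explains this difference.

From the compounds shown here alone, it remains open whether the read-out would hold with a longer chain on this oxygen, such as ethoxy or benzyloxy, or with an amine in place of the oxygen group. With a single concentration per compound, these values also leave open whether compound 3 and compound 4 would separate at other concentrations.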